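Methyl to chloro on the anilide ring of compound 3

The source may report more compounds than this note shows. Statements on the series, on what has been measured and on what is new or still open speak of the compounds shown alone.

Measured so far:
compound 1, `COc1cc2c(Nc3nc4ccc(C(=O)Nc5c(C)cccc5Cl)cc4s3)ncnc2cc1OCCCN1CCCCC1C`, 7000 nM
compound 2, `COc1cc2c(Nc3nc4ccc(C(=O)Nc5c(C)cccc5C)cc4s3)ncnc2cc1OCCCN1CCCC1`, 18900 nM
compound 3, `COc1cc2c(Nc3nc4ccc(C(=O)Nc5c(C)cccc5C)cc4s3)ncnc2cc1OCCCN1CCC(C)CC1`, 11200 nM

In a functional assay on U-937 cells (Homo sapiens) for cytotoxicity, read by WST assay, with a stated time of 72 h (on this read-out higher numbers stand for weaker inhibition and lower numbers for stronger inhibition), compound 3 stands second highest of the three numbers, with compound 1 nearest and compound 2 furthest, both within the scatter of it. Among the measured compounds shown here, the one step among measured compounds, a 1.7-fold lower number from compound 2 to compound 3 (0.23 log units; within the scatter), concerns the amine on the chain and is itself within the scatter.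

Compound 4, `COc1cc2c(Nc3nc4ccc(C(=O)Nc5c(C)cccc5Cl)cc4s3)ncnc2cc1OCCCN1CCC(C)CC1`, differs from compound 3 by chloro in place of methyl on an aromatic carbon. For the measured compounds named here, no measured step isolates this change. Compound 1 carries the same chloro group together with a different amine, and its number and that of compound 3 lie within the scatter of each other, so the pair says nothing about the chloro on its own. On this basis no step beyond the scatter is expected in this assay, and compound 4 is estimated at 8500 nM, between 4000 nM and 18000 nM, meaning an expected step of a 1.3-fold lower number from compound 3 to compound 4 (0.12 log units; within the scatter).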

Compound 4, half-maximal inhibitory concentration: 9200 nM
For compound 4 the middle estimate is 1.1-fold (0.03 log units) below the measured one; the measured number falls inside the stated range.
By their numbers in this assay, from the lowest: compounds 1, 4, 3 and 2 (each within the scatter of the next, the first and the last beyond it).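

In this assay, among the compounds shown here, the change from 2,6-dimethylphenyl to 2-chloro-6-methylphenyl, read for the first time with the amine held constant, comes to a 1.2-fold lower number from compound 3 to compound 4 (0.09 log units; within the scatter), so methyl and chloro at this position cannot be told apart. With the chloro group held constant, 4-methylpiperidin-1-yl in place of 2-methylpiperidin-1-yl gives a 1.3-fold higher number from compound 1 to compound 4 (0.12 log units; within the scatter), so these two amines cannot be told apart either, and the earlier comparison of compound 1 with compound 3, which mixed both changes, is now resolved into single steps. Nothing is available that bears on the cause of either step.

On these data alone, it remains open whether methoxy, trifluoromethyl or plain hydrogen at this position of the anilide ring would give a step beyond the scatter. The same question stands on the chain for a morpholine or a piperazine in place of the piperidine.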